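From Fluoro to Chloro on a Nitrophenyl Ring

The source may hold more compounds than are shown below. What is called first, only, known or untested is meant among the compounds shown, and "the series" means these compounds.

In a functional assay on DU-145 cells (Homo sapiens) for inhibition, read by trypan blue exclusion, with a stated time of 96 h (a higher number here means a weaker inhibitor of growth, a lower number a stronger inhibitor of growth), compound 1 `O=C(/C(=C\c1ccc(F)c([N+](=O)[O-])c1)S(=O)(=O)c1ccc(Br)cc1)c1ccc(Br)cc1` gives 25000 nM. In this assay compound 2 `Cc1ccc(/C=C(/SCc2ccc(Cl)cc2Cl)C(=O)c2ccc(Cl)cc2)s1`, a differently built structure, gives 50000 nM. These two numbers lie within the scatter of each other, so the data do not separate them, and compound 1 stands level with compound 2. Compound 3 `Cc1ccc(S/C(=C/c2cnc3ccccc3c2)C(=O)c2ccc(Cl)cc2)cc1` returns only a limit of the assay, reported as > 100000 nM. Within the data shown here, no two measured compounds differ in one place alone, so the series offers no direct measure of any single change.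

Compound 4 `O=C(/C(=C\c1ccc(Cl)c([N+](=O)[O-])c1)S(=O)(=O)c1ccc(Br)cc1)c1ccc(Br)cc1` is the next to be read. It keeps the core of compound 1 and carries chloro in place of fluoro on an aromatic carbon, ortho to a nitro group and para to a large group, which turns 4-fluoro-3-nitrophenyl into 4-chloro-3-nitrophenyl (chloro in place of fluoro on an aromatic carbon). Among the measured compounds shown here, with no measured step to draw on, the expectation starts from compound 1 at 25000 nM, and no shift beyond the scatter is expected in this assay. The estimated step is a 1.3-fold lower number from compound 1 to compound 4 (0.10 log units; within the scatter). For compound 4 the expected value is 20000 nM, with an estimated range from 8000 nM to 60000 nM.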

Compound 4, concentration for 50% growth inhibition: 10000 nM
The estimate for compound 4 lay 2.0-fold (0.30 log units) above the measured number; the measured number falls inside the stated range.
By their numbers in this assay, from the lowest: compound 4; then compounds 1 and 2 (each within the scatter of the next). At a limit, above all of these: compound 3.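

In this assay, this pair gives the series its first measured single change: a 2.5-fold lower number from compound 1 to compound 4 (0.40 log units; beyond the scatter). Among these compounds, it marks the aromatic carbon ortho to a nitro group and para to a large group as a place where replacing fluoro with chloro moves the number beyond the scatter, though only modestly, something the earlier compounds could not show, as no two of them differed in one place alone. Nothing among the data shown accounts for the lower number with chloro than with fluoro.

What the compounds shown leave open is how other groups on this same carbon would read, among them bromo, a methoxy group, an amine or a carboxylic acid, and so whether the move from fluoro to chloro is part of a wider trend at this position. This single pair also leaves open whether the same exchange would give a similar step on another core, or with the nitro group replaced by a nitrile.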